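The compounds below may be only part of what the source reports. "The series", "measured", "known", "first", "only" and "open" are said of these compounds alone.

Read-outs in an ADME assay on BCBL1 cells (Homo sapiens) for cytotoxicity, with a stated time of 7 days (a higher number here means that more compound is tolerated, a lower number that less compound is tolerated), so far:
compound 1 `CC(C)CSc1nc(N)nc2c1ncn2/C=C1/CC1(CO)CO` gives > 20000 nM
compound 2 `CC(C)Nc1nc(N)nc2c1ncn2/C=C1/CC1(CO)CO` gives > 20000 nM
compound 3 `CCCNc1nc(N)nc2c1ncn2/C=C1/CC1(CO)CO` gives > 20000 nM

All three entries are limits rather than numbers (the limit of > 20000 nM in this assay, at which 3 of the 3 values shown sit). Compound 3 therefore stands at the limit of the assay, with > 20000 nM as its entry and no number to start from.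

Compound 4 `CSc1nc(N)nc2c1ncn2/C=C1/CC1(CO)CO` carries methylsulfanyl in place of propylamino on an aromatic carbon. The nearest measured exchanges swap isobutylsulfanyl for an amino group at that same carbon, and neither has a readable size (a step that the two limits leave unreadable from compound 1 to compound 3; a step that the two limits leave unreadable from compound 1 to compound 2). The step between the two amino chains is no more informative (a step that the two limits leave unreadable from compound 2 to compound 3). Within the data shown here, no measured step therefore gives a size for this change.

The expectation rests mainly on the limit of compound 1 (> 20000 nM), which also carries a sulfanyl group at this carbon. No step beyond the scatter is expected in this assay, and a further limit is the likeliest report. The estimated step is a number no higher from compound 3 to compound 4 (the limit leaves the size open) and it is expected to be small. For compound 4 the estimated value is 20000 nM, with an expected range from 8000 nM to 40000 nM.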

Compound 4, half-maximal cytotoxic concentration: > 20000 nM
Compound 4: only a limit was reported; the forecaster's own chance of this, stated with the estimate: 85%; the middle value lies on the limit itself.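

In this assay compound 4 gives > 20000 nM, a limit and not a number. No step to compound 4 from compound 1, compound 2 or compound 3 can be read, because every entry is a limit: the limit of > 20000 nM in this assay, at which 4 of the 4 values shown sit.

The compounds shown leave open whether exchanging isobutylsulfanyl, isopropylamino, propylamino or methylsulfanyl on this aromatic carbon changes the tolerated concentration at all.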